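Swapping Isopropyl for Butyl on a Shared Core

The source may report more compounds than this note shows. Statements on the series, on what has been measured and on what is new or still open speak of the compounds shown alone.

Among the compounds with values here, in a functional assay on HeLa cells (Homo sapiens) for inhibition, read by MTT assay, with a stated time of 72 h (on this read-out lower numbers stand for stronger inhibition and higher numbers for weaker inhibition), compound 2 `CC(C)c1ccc(C(=O)/C=C/C(=O)O)cc1` gives 4900 nM, the lower of the two numbers measured so far. The other number comes from compound 1 `CCc1ccc(C(=O)/C=C/C(=O)O)cc1`, which gives 27800 nM. Compound 3 `CCCCc1ccc(C(=O)/C=C/C(=O)O)cc1` is still unmeasured and differs from compound 2 in one place: butyl in place of isopropyl on an aromatic carbon. Within the data shown here, only one measured step bears on this change: a 5.7-fold lower number from compound 1 to compound 2 (0.75 log units; beyond the scatter), with methyl in place of hydrogen on a saturated chain carbon. It shows that a small edit to this group can move the number beyond the scatter. However, no measured compound carries butyl, so that step gives no firm direction. In this assay no step beyond the scatter is therefore expected, and the estimate is a 1.2-fold higher number from compound 2 to compound 3 (0.09 log units; within the scatter). For compound 3 the expected value is 6000 nM, with an estimated range from 2000 nM to 18000 nM.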

Compound 3, half-maximal inhibitory concentration: 4780 nM
Compound 3: middle estimate off by 1.3-fold (0.10 log units), on the high side; the range from low to high includes it.
By their numbers in this assay, from the lowest: compounds 3 and 2 (each within the scatter of the next); then compound 1.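

In this assay, butyl in place of isopropyl on an aromatic carbon gives a 1.0-fold lower number from compound 2 to compound 3 (0.01 log units; within the scatter), so this assay does not separate these two groups at this position, even though they differ in shape and in heavy-atom count. Ethyl in place of hydrogen on a saturated chain carbon, two bonds along the chain from an aromatic carbon, gives a 5.8-fold lower number from compound 1 to compound 3 (0.76 log units; beyond the scatter), which shows that a step beyond the scatter from the ethyl group of compound 1 does not depend on adding carbon only at the chain carbon bound to the aromatic carbon. No measurement is available to explain this result.

The compounds shown leave open whether a longer chain such as hexyl would give a number within the scatter of compound 3. Also open, going by these compounds, is how an amine or a phenyl group on the same aromatic carbon would read.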